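The source may report more compounds than this note shows. Statements on the series, on what has been measured and on what is new or still open speak of the compounds shown alone.

For the measured compounds named here, in a functional assay on the whole organism for inhibition, with Rattus norvegicus as the target, read by paw edema, with stated times of 30 min and 4 h, at a dose of 0.28 mmol/kg by the oral route (on this read-out lower numbers stand for less inhibition and higher numbers for more inhibition at the one dose given (going by the name of the read-out)), compound 2, `COc1ccc(NC(=O)c2nc(-c3cc(OC)c(OC)c(OC)c3)n(-c3ccc(OC)cc3)n2)cc1`, gives 63%, the lowest of the two numbers so far, though its only neighbour, compound 1, `CNC(=O)c1nc(-c2cc(OC)c(OC)c(OC)c2)n(-c2ccc(OC)cc2)n1`, gives 65%, and the step of a number 2 percentage points lower from compound 1 to compound 2 (within the scatter) lies within the scatter, so the two cannot be ordered. Compound 3, `COc1ccc(-n2nc(C(=O)Nc3ccc(C)cc3)nc2-c2cc(OC)c(OC)c(OC)c2)cc1`, differs from compound 2 by methyl in place of methoxy on an aromatic carbon. Going by the values given here, no measured step touches this position; the one known step, which swapped a methyl for a 4-methoxyphenyl on the amide-type nitrogen, a number 2 percentage points lower from compound 1 to compound 2 (within the scatter), was itself within the scatter. The exchange of a methoxy for a methyl is a small change on an outer ring, and with nothing in the data pointing either way, the expected step of no change at the digits printed from compound 2 to compound 3 (within the scatter) is none beyond the scatter. Compound 3 is therefore estimated at 63% in this assay, with a range from 50% to 76%.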

Compound 3, a percentage reported as inhibition, in the whole organism at one dose (the size of the read-out at that dose, not a potency): 58%
Estimate against measurement, compound 3: 5 percentage points above, and the stated range covers the measured number.
By their numbers in this assay, from the lowest: compounds 3, 2 and 1 (each within the scatter of the next).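

In this assay, for the compounds shown here, the first measured change at this position, methyl in place of methoxy on an aromatic carbon para to a large group, gives a number 5 percentage points lower from compound 2 to compound 3 (within the scatter), so this exchange does not separate the two compounds. The 4-methylphenyl group on the amide-type nitrogen, in place of methyl, gives a number 7 percentage points lower from compound 1 to compound 3 (within the scatter), so, as with 4-methoxyphenyl, this aromatic group cannot be told apart from the small methyl there. No measurement bears on why these compounds read alike.

The compounds shown leave open whether an amine or a carboxylic acid at this ring position would give a step beyond the scatter. They also leave open whether a longer chain on the amide-type nitrogen would do so at the one dose given.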